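Adding a piperidinyl group to compound 2 in a cytotoxicity test

This account rests on a few compounds, and the source may have more. Where it says the series, first, only, none or still open, it means among the compounds named here.

Compound 1 `CC(=O)Nc1ccc(-c2nc3cc([N+](=O)[O-])ccc3[nH]2)cc1`: > 100000 nM, a limit of the assay.
Compound 2 `CC(=O)Nc1ccc(-c2nc3cc(C(F)(F)F)ccc3[nH]2)cc1`: 19000 nM.
Compound 3 `Fc1ccc(-c2nc3cc(C(F)(F)F)ccc3[nH]2)cc1`: 22000 nM.

In an ADME assay on MT4 cells (Homo sapiens) for cytotoxicity, read by MTT assay, with a stated time of 96 h (on this read-out higher numbers stand for lower toxicity in this test and lower numbers for higher toxicity in this test), compound 2 has the lowest of the two numbers, with compound 3 nearest, a 1.2-fold higher number from compound 2 to compound 3 (0.06 log units; within the scatter). Compound 1 sits at a limit, (the limit of > 100000 nM in this assay, at which 1 of the 3 values shown sits), so the step of an at least 5.2-fold lower number from compound 1 to compound 2 (0.72 log units; beyond the scatter) can only be bounded. Compound 4 `O=C(CN1CCCCC1)Nc1ccc(-c2nc3cc(C(F)(F)F)ccc3[nH]2)cc1` differs from compound 2 by piperidin-1-yl in place of hydrogen on a saturated chain carbon bound to a carbonyl carbon. Neither measured step touches the acetamido group in this way; the step from compound 2 to compound 3 replaced that group entirely and stayed within the scatter, while the step from compound 1 to compound 2 concerned the ring substituent. Within the data shown here, with no closer precedent, compound 4 is expected to give a number within the scatter of compound 2, a 1.3-fold lower number from compound 2 to compound 4 (0.10 log units; within the scatter), and its estimate is 15000 nM, between 5000 nM and 40000 nM.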

Compound 4, half-maximal cytotoxic concentration: 6000 nM
Beside the measured number, compound 4's estimate is 2.5-fold (0.40 log units) above it; the range from low to high includes it.
By their numbers in this assay, from the lowest: compound 4; then compounds 2 and 3 (each within the scatter of the next). At a limit, above all of these: compound 1.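

In this assay, piperidin-1-yl on the saturated chain carbon bound to a carbonyl carbon gives a 3.2-fold lower number from compound 2 to compound 4 (0.50 log units; beyond the scatter), a modest move toward higher toxicity in this test. This position therefore responds to a change, which the replacement of the whole acetamido group, with a 1.2-fold higher number from compound 2 to compound 3 (0.06 log units; within the scatter), did not show. Nothing measured here accounts for this shift.

On these data alone, whether the shift belongs to piperidin-1-yl itself or would also follow from another amine on this carbon, such as morpholine or dimethylamino, stays open. So does the effect of a longer chain carrying the piperidine.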